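Amino to Methoxy Swap in Four Related Compounds

The source may hold more compounds than are shown below. What is called first, only, known or untested is meant among the compounds shown, and "the series" means these compounds.

Compounds 1, 2 and 3 have been tested in a functional assay on MCF7 cells (Homo sapiens) for inhibition, read by MTT assay, with a stated time of 2 days; a higher number here means a weaker inhibitor, a lower number a stronger inhibitor. For the measured compounds named here, compound 3 `Nc1ccc(/C=C/c2ccccc2O)cc1` gives 23 ug/mL, and compound 1 `COc1ccc(/C=C/c2ccccc2O)cc1` gives 17 ug/mL; the only change between them is methoxy in place of amino on an aromatic carbon, which made a step of a 1.4-fold lower number from compound 3 to compound 1 (0.13 log units; within the scatter). Compound 2 `Nc1cccc(/C=C/c2ccc(O)cc2)c1` gives 6 ug/mL; the difference between the core of compound 2 and the core of compound 3 is not broken down here. Compound 4 `COc1cccc(/C=C/c2ccc(O)cc2)c1` has not yet been measured. It differs from compound 2 by methoxy in place of amino on an aromatic carbon. Going by the values given here, this is the same kind of change as the one from compound 3 to compound 1, but the place is not the same: there the group stands para to a group of 9 heavy atoms, here meta to it. Because the earlier step was a 1.4-fold lower number from compound 3 to compound 1 (0.13 log units; within the scatter), a similarly small step is expected in this assay, a 1.2-fold lower number from compound 2 to compound 4 (0.08 log units; within the scatter). Compound 4 is therefore estimated at 5 ug/mL, most likely between 2.5 ug/mL and 12 ug/mL.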

Compound 4, half-maximal inhibitory concentration: 21 ug/mL
Compound 4: the middle estimate sits 4.2-fold (0.62 log units) below what was measured; the whole stated range lies below it.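

On the core of compound 2, methoxy in place of amino gave a 3.5-fold higher number from compound 2 to compound 4 (0.54 log units; beyond the scatter) in this assay, so compound 4 is the weaker inhibitor of the pair. The same swap therefore did not carry over with the same size from one core to the other: the same change on two cores in this assay, a 1.4-fold lower number (0.13 log units; within the scatter) from compound 3 to compound 1 and a 3.5-fold higher number (0.54 log units; beyond the scatter) from compound 2 to compound 4, 4.7-fold (0.68 log units) apart, beyond the scatter of two such steps. This does not show why the two steps differ, since the cores differ and the group also stands in a different place on each, and two steps cannot separate those influences.

Still open, on these data alone, is how a third core would respond to this swap. Also open, as far as these compounds go, is whether a group such as ethoxy or dimethylamino, at the same place, would follow amino or methoxy on either core.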